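Lengthening the Sulfur-Linked Chain of Compound 2

This account rests on a few compounds, and the source may have more. Where it says the series, first, only, none or still open, it means among the compounds named here.

Compound 1, `Cc1cc(N2CC[C@@H](C)[C@@H](N(C)c3ncnc4[nH]ccc34)C2)n2nc(SCc3ccc(Cl)cc3)nc2n1`: in a toxicity assay on GES1 cells (Homo sapiens) for inhibition, read by MTT assay, with a stated time of 72 h (a higher number here means a weaker inhibitor, a lower number a stronger inhibitor), compound 1 gives only a limit, > 100000 nM.
Compound 2, `Cc1cc(N2CC[C@@H](C)[C@@H](N(C)c3ncnc4[nH]ccc34)C2)n2nc(SCCc3ccccc3)nc2n1`: in this assay compound 2 gives 66200 nM.
Compound 3, `C=CCSc1nc2nc(C)cc(N3CC[C@@H](C)[C@@H](N(C)c4ncnc5[nH]ccc45)C3)n2n1`: in this assay compound 3 gives only a limit, > 100000 nM.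

Compound 2 is the only one of the three with a true number in this assay; the other two stand at the assay's ceiling, (the limit of > 100000 nM in this assay, at which 2 of the 3 values shown sit). The steps among them are therefore thin: an at least 1.5-fold lower number from compound 1 to compound 2 (0.17 log units; that floor lies within the scatter), an at least 1.5-fold higher number from compound 2 to compound 3 (0.17 log units; that floor lies within the scatter), and a step that the two limits leave unreadable from compound 1 to compound 3. Neither readable step reaches beyond the scatter.

Compound 4, `Cc1cc(N2CC[C@@H](C)[C@@H](N(C)c3ncnc4[nH]ccc34)C2)n2nc(SCCCc3ccccc3)nc2n1`, differs from compound 2 by benzyl in place of phenyl on a saturated chain carbon, two bonds along the chain from a sulfur. All three measured steps change the group directly on the carbon bound to sulfur, whereas compound 4 keeps that group and only extends the chain by one carbon, so none of them speaks directly to this change. With the nearest comparisons, from compound 1 to compound 2 and from compound 2 to compound 3, both giving only floors within the scatter, no shift beyond the scatter is expected in this assay in either direction.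

Compound 4 is therefore estimated at 75000 nM, with an expected range from 30000 nM to 160000 nM. That estimate means a 1.1-fold higher number from compound 2 to compound 4 (0.05 log units; within the scatter) is expected, and a reading at the limit rather than a number is also plausible.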

Compound 4, half-maximal inhibitory concentration: > 100000 nM
Compound 4 was reported as a limit (the forecaster's own chance of this, stated with the estimate: 40%); middle value at least 1.3-fold (0.12 log units) from the limit.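

Compound 4 extends the phenethylsulfanyl chain of compound 2 to (3-phenylpropyl)sulfanyl, which makes this the only comparison shown in this assay where the chain grows while its phenyl end stays, and it gives an at least 1.5-fold higher number from compound 2 to compound 4 (0.17 log units; that floor lies within the scatter). For the compounds shown here, compound 4 gives a limit and not a number, so lengthening the chain at this position produces no shift that can be read beyond the scatter, and compound 2 remains the only compound here with a true number. The steps from compound 3 to compound 4 and from compound 1 to compound 4 cannot be read, because both ends of each step are limits: the limit of > 100000 nM in this assay, at which 3 of the 4 values shown sit.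

The compounds shown leave open how large the step from compound 2 to compound 4 really is, and whether any change in this sulfur-linked chain moves the number beyond the scatter in this assay. They also leave open what a still longer chain would give, or an amine or a carboxylic acid carried at the end of the 3-phenylpropyl chain in place of its phenyl.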